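Swapping the aryl for an isobutyl chain

This account rests on a few compounds, and the source may have more. Where it says the series, first, only, none or still open, it means among the compounds named here.

Measured so far:
compound 1, `Cc1ccc(Cn2c(CN3CCN(C(=O)C4CC4)CC3)nc3ccccc32)cc1`, 51.5%
compound 2, `Cc1cccc(Cn2c(OC3CCN(C(=O)C4CC4)CC3)nc3ccccc32)c1`, 80.6%

Both compounds were tested in an assay on isolated protein for inhibition of aldehyde dehydrogenase 1A1 (Homo sapiens), read by spectrophotometry, tested at 10 uM; on this read-out lower numbers stand for less inhibition and higher numbers for more inhibition at the one concentration tested (going by the name of the read-out). Compound 1 gives the lower of the two numbers; compound 2 stands higher by a margin beyond the usual scatter of such measurements. The unmeasured compound 3, `CC(C)CCn1c(CN2CCN(C(=O)C3CC3)CC2)nc2ccccc21`, keeps the core of compound 1 and changes only one part: isobutyl in place of 4-methylphenyl on a saturated chain carbon bound to an aromatic nitrogen. For the measured compounds named here, a ring-bearing group is thus replaced by a shorter, ring-free chain, and no measured pair shows what such a swap does here. Without a comparable step in hand, the expectation is only a guess, and a modest loss of inhibition seems as likely as no change beyond the scatter. The step from compound 1 to compound 3 is expected to be a number 11.5 percentage points lower from compound 1 to compound 3 (beyond the scatter). Compound 3 is therefore estimated at 40%, with a plausible range from 15% to 65%.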

Compound 3, a percentage reported as inhibition, at one concentration (the size of the read-out at that concentration, not a potency): 70%
Compound 3: the middle estimate sits 30 percentage points below what was measured; the measured number lies above the stated range.
By their numbers in this assay, from the lowest: compound 1; then compound 3; then compound 2.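

Replacing 4-methylphenyl with isobutyl on a saturated chain carbon bound to an aromatic nitrogen gives, in this assay, a number 18.5 percentage points higher from compound 1 to compound 3 (beyond the scatter). For the compounds shown here, this is the first comparison here in which only one place changes, and it shows that an aromatic ring at this place is not required for inhibition at the one concentration tested: a smaller, ring-free group gives the higher number. Nothing available explains why this swap raises the number.

With isobutyl as the only ring-free group shown at this place, it remains open whether a longer chain, or a chain ending in an amine or a carboxylic acid, would raise or lower the number. Going by these compounds, it is also open whether the same swap would produce a similar step on compound 2.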